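The source may hold more compounds than are shown below. What is called first, only, known or untested is meant among the compounds shown, and "the series" means these compounds.

Compound 1 `O=C1COc2ccc(-c3cnc(Cl)c(NS(=O)(=O)c4ccc(F)cc4)c3)cc2N1c1ccc(Cl)cc1` sits second highest of the three numbers in a functional assay on A549 cells (Homo sapiens) for antiproliferative activity, read by MTT assay, with a stated time of 72 h (on this read-out lower numbers stand for stronger inhibition and higher numbers for weaker inhibition), giving 21600 nM; compound 3 `COc1ncc(-c2ccc3c(c2)N(C2CCCCC2)C(=O)CO3)cc1NS(=O)(=O)c1ccc(F)cc1` gives 24600 nM, within the scatter of compound 1, while compound 2 `COc1ncc(-c2ccc3c(c2)N(c2ccc(Cl)cc2)C(=O)CO3)cc1NS(=O)(=O)c1ccc(F)cc1` gives 8350 nM, the furthest away. The step of a 2.6-fold lower number from compound 1 to compound 2 (0.41 log units; beyond the scatter) came from a methoxy in place of chloro on an aromatic carbon. Compound 4 `O=C1COc2ccc(-c3cnc(Cl)c(NS(=O)(=O)c4ccc(F)cc4)c3)cc2N1` differs from compound 1 by hydrogen in place of 4-chlorophenyl on an amide-type nitrogen in a ring. Among the measured compounds shown here, the only step touching that nitrogen is a 2.9-fold higher number from compound 2 to compound 3 (0.47 log units; beyond the scatter), where cyclohexyl replaced 4-chlorophenyl and the number rose modestly. Since no hydrogen at that position has been measured, the step of a 2.3-fold higher number from compound 1 to compound 4 (0.36 log units; beyond the scatter) is expected to run in the same direction, weakening. Compound 4 is therefore estimated at 50000 nM, ranging from 15000 nM to 150000 nM.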

Compound 4, half-maximal inhibitory concentration: > 40000 nM
Compound 4 ended at the assay's limit; the forecaster's own chance of this, stated with the estimate: 25%; the middle value lies beyond the limit too.
By their numbers in this assay, from the lowest: compound 2; then compounds 1 and 3 (each within the scatter of the next). At a limit, above all of these: compound 4.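

In this assay, compound 4 gives only a limit rather than a number: the limit of > 40000 nM in this assay, at which 1 of the 4 values shown sits. Earlier, the amide-type nitrogen had been seen only carrying a ring, whereas this result shows it with hydrogen and without the 4-chlorophenyl; the step is an at least 1.8-fold higher number from compound 1 to compound 4 (0.26 log units; that floor lies within the scatter). Its floor lies within the scatter, so a real loss on removing the 4-chlorophenyl is allowed but not established. The compounds shown leave open whether a methyl group or a longer chain such as n-butyl on that nitrogen would give a measurable number.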